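The source may report more compounds than this note shows. Statements on the series, on what has been measured and on what is new or still open speak of the compounds shown alone.

Of the compounds shown here, three of one series have been tested in an ADME assay on MT4 cells (Homo sapiens) for cytotoxicity, read by MTT assay, with a stated time of 5 days; on this read-out higher numbers stand for lower toxicity in this test and lower numbers for higher toxicity in this test. Compound 1 `CCNC(c1ccnc(Nc2ccc(C#N)cc2)n1)c1ccccc1Cl` gives 39400 nM. Compound 3 `CC(C)NC(c1ccnc(Nc2ccc(C#N)cc2)n1)c1ccccc1Cl`, in which methyl replaces hydrogen on a saturated chain carbon bound to an amine nitrogen and a saturated chain carbon, gives 35500 nM, and the step of a 1.1-fold lower number from compound 1 to compound 3 (0.05 log units; within the scatter) stays within the scatter. Compound 2 `CCCNC(c1ccc(C#N)cc1)c1ccnc(Nc2ccc(C#N)cc2)n1` gives 34900 nM, a number that lies within the scatter of both compound 1 and compound 3, so the three compounds are not distinguished by this assay.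

Compound 4 `CCCNC(c1ccc(/C=C/C#N)cc1)c1ccnc(Nc2ccc(C#N)cc2)n1` differs from compound 2 in one place: 2-cyanoethenyl in place of cyano on an aromatic carbon. Read one bond further out, 4-cyanophenyl becomes 4-(2-cyanoethenyl)phenyl. Among the compounds with values here, no measured step touches this part of the molecule; the single measured step, from a change at the amine, was within the scatter. The expectation for compound 4 is therefore a step of a 1.0-fold higher number from compound 2 to compound 4 (0.00 log units; within the scatter), nothing beyond the scatter. Compound 4 is estimated at 35000 nM, with a range from 17000 nM to 72000 nM.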

Compound 4, half-maximal cytotoxic concentration: 34000 nM
Beside the measured number, compound 4's estimate is 1.0-fold (0.01 log units) above it, within the range that was stated.
By their numbers in this assay, from the lowest: compounds 4, 2, 3 and 1 (each within the scatter of the next).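

Until now only a change at the amine had been read. In this assay, within the data shown here, this pair is the first to touch the aromatic carbon para to a large group, where 2-cyanoethenyl in place of cyano gives a 1.0-fold lower number from compound 2 to compound 4 (0.01 log units; within the scatter), so compound 4 is not told apart from compound 2 at this position even though the entering group is larger and brings a double bond outside aromatic rings. Nothing measured here offers a reason for this result.

The compounds shown leave open whether a group of another kind on this aromatic carbon, such as an amine or a carboxylic acid, would move the number beyond the scatter. They also leave open whether 2-cyanoethenyl would read the same alongside a longer chain on the amine nitrogen.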